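Swapping Chlorine for Bromine on the Anilide Ring

The compounds below may be only part of what the source reports. "The series", "measured", "known", "first", "only" and "open" are said of these compounds alone.

Compound 1: `Cc1ccc(NC(=O)/C(C#N)=C\Nc2ccc(S(=O)(=O)Nc3cc(C)on3)cc2)cc1` gives 50900 nM in a functional assay on MCF7 cells (Homo sapiens) for inhibition, read by sulforhodamine B assay, with a stated time of 72 h; on this read-out lower numbers stand for stronger inhibition and higher numbers for weaker inhibition.
Compound 2: `Cc1cc(NS(=O)(=O)c2ccc(N/C=C(/C#N)C(=O)Nc3ccc(Cl)cc3)cc2)no1` gives 28400 nM in this assay.

Compound 2 holds the lowest number of these two, though the step of a 1.8-fold lower number from compound 1 to compound 2 (0.25 log units; within the scatter) lies within the scatter. Compound 3, `Cc1cc(NS(=O)(=O)c2ccc(N/C=C(/C#N)C(=O)Nc3ccc(Br)cc3)cc2)no1`, differs from compound 2 by bromo in place of chloro on an aromatic carbon, sitting on an aromatic carbon of a six-membered aromatic ring of carbon only, para to a large group. For the measured compounds named here, the only measured step, a 1.8-fold lower number from compound 1 to compound 2 (0.25 log units; within the scatter), touched the same carbon and stayed within the scatter, so exchanging one halogen for another is expected to move this assay by no more than the scatter. Compound 3 is therefore estimated at 25000 nM, between 10000 nM and 60000 nM. For compound 3 that expected step is a 1.1-fold lower number from compound 2 to compound 3 (0.06 log units; within the scatter).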

Compound 3, half-maximal inhibitory concentration: 14000 nM
The estimate for compound 3 lay 1.8-fold (0.25 log units) above the measured number; measured number inside the range.
By their numbers in this assay, from the lowest: compound 3; then compounds 2 and 1 (each within the scatter of the next).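

Exchanging one halogen for the other at this ring carbon gives a 2.0-fold lower number from compound 2 to compound 3 (0.31 log units; beyond the scatter) in this assay, a modest step but one beyond the scatter, which the earlier change from methyl to chloro did not reach. Bromo in place of methyl gives a 3.6-fold lower number from compound 1 to compound 3 (0.56 log units; beyond the scatter) and so confirms that this carbon can register a change. No supporting data bear on why the number falls with bromo.

On these data alone, whether an iodo, methoxy or carboxylic acid group at this carbon would give a lower or higher number stays open. So does whether the bromo step would hold on a different core.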